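The source may hold more compounds than are shown below. What is called first, only, known or untested is meant among the compounds shown, and "the series" means these compounds.

In a functional assay on HepG2 cells (Homo sapiens) for cytotoxicity, read by MTT assay, with a stated time of 48 h (on this read-out lower numbers stand for stronger inhibition and higher numbers for weaker inhibition), compound 1 `Cc1ncc([N+](=O)[O-])n1CCSc1nnc(-c2ccccc2N)o1` gives 4500 nM, the second highest of three numbers: compound 2 `Cc1ncc([N+](=O)[O-])n1CCSc1nnc(-c2ccccc2[N+](=O)[O-])o1` gives 700 nM, while compound 3 `COc1cc(-c2nnc(SCCn3c([N+](=O)[O-])cnc3C)o2)cc(OC)c1OC` gives 14900 nM. Compound 4 `Cc1ncc([N+](=O)[O-])n1CCSc1nnc(-c2cccnc2)o1` differs from compound 1 in one place: pyridin-3-yl in place of 2-aminophenyl on an aromatic carbon. Within the data shown here, no measured step covers this exact exchange. Among the measured compounds shown here, the only single-point step, a 6.4-fold lower number from compound 1 to compound 2 (0.81 log units; beyond the scatter), shows that nitro in place of amino on an aromatic carbon lowered the number; compound 4 also loses the amino group but gains no nitro group, so that step guides only loosely. The step expected for compound 4 is a 1.3-fold lower number from compound 1 to compound 4 (0.11 log units; within the scatter), a small change that may well stay within the scatter. Compound 4 is therefore estimated at 3500 nM, with a range from 1200 nM to 10000 nM.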

Compound 4, half-maximal inhibitory concentration: 9600 nM
Estimate against measurement, compound 4: 2.7-fold (0.44 log units) below; measured number inside the range.
By their numbers in this assay, from the lowest: compound 2; then compound 1; then compounds 4 and 3 (each within the scatter of the next).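

Pyridin-3-yl in place of 2-aminophenyl gives a 2.1-fold higher number from compound 1 to compound 4 (0.33 log units; beyond the scatter) in this assay and so shows that an exchange removing the amino group can also raise the number, unlike the nitro exchange in compound 2. This position therefore responds to replacing the whole ring, not only to changing the group on it. No measurement here explains the rise. Going by these compounds, the ring nitrogen and the loss of the amino group arrive together in compound 4, so their separate shares stay open. A plain phenyl group at this position would help to separate them.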